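Swapping the aryl group on the amide-type nitrogen

The source may report more compounds than this note shows. Statements on the series, on what has been measured and on what is new or still open speak of the compounds shown alone.

In a functional assay on K562 cells (Homo sapiens) for inhibition, read by MTT assay, with a stated time of 48 h (a higher number here means a weaker inhibitor, a lower number a stronger inhibitor), compound 1 `CC(=O)Nc1nc2ccc(-c3cn([C@@H]4CN[C@H](C(=O)Nc5ccc(Cl)c(C(F)(F)F)c5)C4)nn3)nc2s1` gives 10000 nM. Compound 2 `O=C(Nc1nc2ccc(-c3cn([C@@H]4CN[C@H](C(=O)Nc5ccc(Cl)c(C(F)(F)F)c5)C4)nn3)nc2s1)C1CC1` gives 16200 nM in this assay, within the scatter of compound 1. For the measured compounds named here, the one measured step, a 1.6-fold higher number from compound 1 to compound 2 (0.21 log units; within the scatter), is cyclopropyl in place of methyl on a carbonyl carbon and is within the scatter.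

Compound 3 `O=C(Nc1nc2ccc(-c3cn([C@@H]4CN[C@H](C(=O)Nc5ccc(Br)cc5)C4)nn3)nc2s1)C1CC1` keeps the cyclopropyl and differs from compound 2 as follows: 4-bromophenyl in place of 4-chloro-3-(trifluoromethyl)phenyl on an amide-type nitrogen. In words, this is 4-bromophenyl in place of 4-chloro-3-(trifluoromethyl)phenyl on an amide-type nitrogen. Going by the values given here, no measured pair varies this group, and the one measured step lies at a different place, so it gives neither a size nor a direction for this change. The expectation therefore starts from compound 2 at 16200 nM, with no step beyond the scatter and a wide range.

The expected change is a 1.2-fold lower number from compound 2 to compound 3 (0.06 log units; within the scatter). For compound 3 the estimate is 14000 nM, with an expected range of 5500 nM to 40000 nM.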

Compound 3, half-maximal inhibitory concentration: 8160 nM
Estimate against measurement, compound 3: 1.7-fold (0.23 log units) above; measured number inside the range.
By their numbers in this assay, from the lowest: compounds 3, 1 and 2 (each within the scatter of the next).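

In this assay, for the compounds shown here, the swap of 4-chloro-3-(trifluoromethyl)phenyl for 4-bromophenyl on the amide-type nitrogen gives a 2.0-fold lower number from compound 2 to compound 3 (0.30 log units; within the scatter) and is the first measured step at this position. The group falls from 11 heavy atoms to 7 and loses both the chlorine and the trifluoromethyl, yet the number stays within the scatter, so this one pair shows no measurable dependence on that difference. No measured information bears on why the two aryl groups read alike.

With one pair at this position, the contributions of the chlorine, bromine and trifluoromethyl cannot be separated. Also open, on these data alone, is whether plain phenyl, 4-chlorophenyl, a carboxylic acid or amine on the phenyl ring, or cyclohexyl in place of the aryl group would move the number beyond the scatter.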